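Notes on a group change at the sulfonyl sulfur

The source may report more compounds than this note shows. Statements on the series, on what has been measured and on what is new or still open speak of the compounds shown alone.

- compound 1 `CC(O)(CSc1cccc(C(F)(F)F)c1)C(=O)Nc1cc(C(F)(F)F)cc(C(F)(F)F)c1` gives 10000 nM in a functional assay on DU-145 cells (Homo sapiens) for antiproliferative activity, read by fluorescence and propidium iodide staining, with a stated time of 96 h; on this read-out higher numbers stand for weaker inhibition and lower numbers for stronger inhibition
- compound 2 `CC(O)(CS(=O)(=O)c1cccc(C(F)(F)F)c1)C(=O)Nc1cc(C(F)(F)F)cc(C(F)(F)F)c1` gives 11500 nM in this assay

On these two numbers, compound 2 lies within the scatter of compound 1, so neither ranks ahead. Compound 3 `CC(O)(CS(=O)(=O)c1ccccc1OC(F)(F)F)C(=O)Nc1cc(C(F)(F)F)cc(C(F)(F)F)c1` carries 2-(trifluoromethoxy)phenyl in place of the 3-(trifluoromethyl)phenyl of compound 2 on a sulfonyl sulfur (2-(trifluoromethoxy)phenyl in place of 3-(trifluoromethyl)phenyl on a sulfonyl sulfur). No measured pair sizes this exchange, so no shift beyond the scatter is expected in this assay in either direction. The expected step of a 1.2-fold lower number from compound 2 to compound 3 (0.06 log units; within the scatter) is small, and the uncertainty around it is wide. Compound 3 is estimated at 10000 nM (4000 nM to 25000 nM).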

Compound 3, half-maximal inhibitory concentration: 12900 nM
Estimate against measurement, compound 3: 1.3-fold (0.11 log units) below, and the stated range covers the measured number.
By their numbers in this assay, from the lowest: compounds 1, 2 and 3 (each within the scatter of the next).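

In this assay, putting 2-(trifluoromethoxy)phenyl in place of 3-(trifluoromethyl)phenyl on a sulfonyl sulfur gives a 1.1-fold higher number from compound 2 to compound 3 (0.05 log units; within the scatter). Within the data shown here, this is the first sized exchange at this position, and it shows that a different aryl group, with one hydrogen-bond acceptor where the old group had none, leaves the number within the scatter. Nothing available explains this result.

This single step changes both the substituent and its ring position, so their contributions cannot be separated. As far as these compounds go, whether a carboxylic acid, an amine or a longer alkyl chain on the sulfonyl sulfur would move the number beyond the scatter remains open.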